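This account rests on a few compounds, and the source may have more. Where it says the series, first, only, none or still open, it means among the compounds named here.

Measured in an assay on RBL cells for inhibition of Polyunsaturated fatty acid 5-lipoxygenase (Rattus norvegicus); a lower number here means a stronger inhibitor, a higher number a weaker inhibitor:
- compound 1 `COC(=O)CCCC(=O)N(O)C(C)c1ccc2oc(-c3ccccc3)cc2c1`: 60 nM
- compound 2 `CC(c1ccc2oc(-c3ccccc3)cc2c1)N(O)C(N)=O`: 410 nM

Compound 2 stands highest of the two numbers in this assay; its nearest neighbour is compound 1, and the step of a 6.8-fold higher number from compound 1 to compound 2 (0.83 log units; beyond the scatter) is beyond the scatter. Compound 3 `COCC(=O)N(O)C(C)c1ccc2oc(-c3ccccc3)cc2c1` is not yet measured. It differs from compound 2 by methoxymethyl in place of amino on a carbonyl carbon, so the carbamoyl of compound 2 becomes a (methoxymethyl)carbonyl. Among the compounds with values here, the only measured step that bears on this is a 6.8-fold higher number from compound 1 to compound 2 (0.83 log units; beyond the scatter), where the carbon-bearing substituent on the carbonyl of compound 1 was exchanged for amino and the number rose modestly. Compound 3 puts a carbon substituent back on that carbonyl, so a step in the opposite direction, of roughly comparable size and beyond the scatter, is expected: a 4.1-fold lower number from compound 2 to compound 3 (0.61 log units; beyond the scatter). Compound 3 is therefore estimated at 100 nM in this assay, in the range 40 nM to 250 nM.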

Compound 3, half-maximal inhibitory concentration: 160 nM
Estimate against measurement, compound 3: 1.6-fold (0.20 log units) below, within the range that was stated.
By their numbers in this assay, from the lowest: compound 1; then compound 3; then compound 2.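

In this assay, methoxymethyl in place of amino on the carbonyl carbon gives a 2.6-fold lower number from compound 2 to compound 3 (0.41 log units; beyond the scatter), so the fall in the number seen with the substituent of compound 1 does not need the whole 3-(methoxycarbonyl)propyl group. That group still counts for something: the change to the methoxymethyl group gives a 2.7-fold higher number from compound 1 to compound 3 (0.43 log units; beyond the scatter), which leaves compound 1 with the lowest number of the three and places compound 3 between the other two, with each step beyond the scatter. Nothing available accounts for either step.

Still open, from the compounds shown here alone, is whether the ester in compound 1 matters, or only the length of its chain; a carboxylic acid at the chain end and a plain butyl chain would separate the two. Also open, going by these compounds, is whether a simple methyl on the carbonyl, with no ether oxygen, would behave like methoxymethyl.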